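Benzimidazole for dimethylpyrazole at the aminopyridine headgroup

A few compounds are considered here, and "the series" means these few. Any claim that something is new, unique, unknown or untested is made for them only; others in the source may bear on it.

Compound 1, `CC(Oc1cccnc1Nc1cnn(C)c1)c1cccc(C(=O)NCc2ccccc2S(=O)(=O)C(C)C)c1`, in a functional assay on NCI-H3122 cells (Homo sapiens) for antiproliferative activity, read by MTT assay, with a stated time of 48 h (on this read-out higher numbers stand for weaker inhibition and lower numbers for stronger inhibition), gives > 100000 nM, a limit of the assay.
Compound 2, `Cc1ccc(CNC(=O)c2cccc(C(C)Oc3cccnc3Nc3ncc(C)s3)c2)cc1`, gives 8500 nM.
Compound 3, `Cc1ccc(CNC(=O)c2cccc(C(C)Oc3ccnc(Nc4cn(C)nc4C)c3)c2)cc1`, gives 13400 nM.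

Compound 3 and compound 2 sit within the usual scatter of each other, so neither stands apart from the other on these numbers; compound 1 is recorded only as a limit (the limit of > 100000 nM in this assay, at which 1 of the 3 values shown sits). Compound 4, `Cc1ccc(CNC(=O)c2cccc(C(C)Oc3ccnc(Nc4nc5ccccc5[nH]4)c3)c2)cc1`, differs from compound 3 by 1H-benzimidazol-2-yl in place of 1,3-dimethyl-1H-pyrazol-4-yl on a nitrogen on an aromatic ring. For the measured compounds named here, no measured pair shows this change, so no measured step fixes its size. The estimate therefore rests on compound 3 alone, with a modest shift toward stronger inhibition expected, close to the scatter. In this assay compound 4 is expected to give 6000 nM, within 1500 nM to 30000 nM, an estimated step of a 2.2-fold lower number from compound 3 to compound 4 (0.35 log units; beyond the scatter).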

Compound 4, half-maximal inhibitory concentration: 9400 nM
Compound 4: middle estimate off by 1.6-fold (0.19 log units), on the low side; the range from low to high includes it.
By their numbers in this assay, from the lowest: compounds 2, 4 and 3 (each within the scatter of the next). At a limit, above all of these: compound 1.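

In this assay, 1H-benzimidazol-2-yl in place of 1,3-dimethyl-1H-pyrazol-4-yl on a nitrogen on an aromatic ring gives a 1.4-fold lower number from compound 3 to compound 4 (0.15 log units; within the scatter) and so does not separate the two groups. This place therefore accepts an added six-membered aromatic ring of carbon only and a hydrogen-bond donor with no change beyond the scatter. Nothing measured here explains this result.

Going by these compounds, whether the hydrogen-bond donor of the 1H-benzimidazol-2-yl group contributes remains open. Also open, on these data alone, is whether a phenyl or a carboxylic acid-bearing group in this place would move the number beyond the scatter.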